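A few compounds are considered here, and "the series" means these few. Any claim that something is new, unique, unknown or untested is made for them only; others in the source may bear on it.

Compound 1 `Nc1ccccc1NC(=O)/C=C/c1ccc(CSc2cccc(F)c2)cc1`: 3.22%
Compound 2 `Nc1ccccc1NC(=O)c1ccc(CSc2cccc(F)c2)cc1`: 81.4%

In a functional assay on HCT-116 cells (Homo sapiens) for inhibition, read by CCK-8 assay, with a stated time of 72 h, tested at 8 uM (on this read-out lower numbers stand for less inhibition of growth and higher numbers for more inhibition of growth at the one concentration tested), compound 2 gives 81.4%, the higher of the two numbers. Compound 1 gives 3.22%, a gap well beyond the usual scatter.

Compound 3 `Nc1ccccc1NC(=O)c1ccc(CSc2ccc(F)cc2)cc1` has 4-fluorophenyl in place of the 3-fluorophenyl of compound 2 on a sulfur: 4-fluorophenyl in place of 3-fluorophenyl on a sulfur. Among the measured compounds shown here, no measured pair here shows what this exchange does, so the expectation rests on compound 2 alone, at 81.4%. The expected result in this assay is a small drop that stays within the scatter, with the estimated step being a number 5.4 percentage points lower from compound 2 to compound 3 (within the scatter). For compound 3, the estimated value is 76%, with an expected range of 55% to 92%.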

Compound 3, percent growth inhibition at one concentration: 90.6%
Compound 3: middle estimate off by 14.6 percentage points, on the low side, and the stated range covers the measured number.
By their numbers in this assay, from the lowest: compound 1; then compounds 2 and 3 (each within the scatter of the next).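

In this assay the exchange of 3-fluorophenyl for 4-fluorophenyl on the sulfur gives a number 9.2 percentage points higher from compound 2 to compound 3 (within the scatter), so this spot accepts either fluorophenyl group without a change that can be told from ordinary scatter. Compound 2 and compound 3 therefore read as equals here. No independent measurement bears on this result.

The compounds shown leave open whether the fluorine matters at all, as a plain phenyl or a 4-chlorophenyl would test. They also leave open whether an oxygen could replace the sulfur.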